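Methoxy step in a lipoyl-triazole-coumarin cytotoxicity series

This account rests on a few compounds, and the source may have more. Where it says the series, first, only, none or still open, it means among the compounds named here.

Measured so far:
compound 1 `O=C(CCCCC1CCSS1)NCc1cn(CCCCOc2ccc3cc(-c4ccccc4)c(=O)oc3c2)nn1`: 30.5%
compound 2 `COc1ccc(-c2cc3ccc(OCCCCn4cc(CNC(=O)CCCCC5CCSS5)nn4)cc3oc2=O)cc1`: 48.6%
compound 3 `O=C(CCCCC1CCSS1)NCc1cn(CCCCCOc2ccc3cc(-c4ccccc4)c(=O)oc3c2)nn1`: 26.3%

In a functional assay on PC-12 cells (Rattus norvegicus) for cytotoxicity, read by MTT assay, with stated times of 3 h and 2 h, tested at 10 uM (on this read-out higher numbers stand for a stronger effect at the one concentration tested and lower numbers for a weaker effect), compound 1 gives 30.5% and compound 2 gives 48.6%. The two differ by one change, (methoxy in place of hydrogen on an aromatic carbon), and the step is a number 18.1 percentage points higher from compound 1 to compound 2 (beyond the scatter). Compound 3, with its own core, gives 26.3% in this assay; its value and that of compound 1 lie within the scatter of each other, so nothing is read into their order. The difference between the core of compound 3 and the core of compound 1 is not broken down here.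

Compound 4 `COc1ccc(-c2cc3ccc(OCCCCCn4cc(CNC(=O)CCCCC5CCSS5)nn4)cc3oc2=O)cc1` is not yet measured. It stands to compound 3 as compound 2 stands to compound 1: the change is methoxy in place of hydrogen on an aromatic carbon, at the same place as before, so it is the same change made on a second core. Among the compounds with values here, the one measured instance of it, the step from compound 1 to compound 2, is the only basis available; with the cores differing in an uncounted way, the expected step is taken as similar in direction and size but with a wide range.

The expected step is a number 17.7 percentage points higher from compound 3 to compound 4 (beyond the scatter), resting on the step from compound 1 to compound 2 being a number 18.1 percentage points higher from compound 1 to compound 2 (beyond the scatter). In this assay compound 4 is therefore estimated at 44%, within an expected range from 30% to 58%.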

Compound 4, a percentage reported as activity, at one concentration (the size of the read-out at that concentration, not a potency): 45.5%
Estimate against measurement, compound 4: 1.5 percentage points below, and the stated range covers the measured number.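

In this assay, the change from phenyl to 4-methoxyphenyl gives a number 19.2 percentage points higher from compound 3 to compound 4 (beyond the scatter) and so carries from the core of compound 1 to the core of compound 3 with no readable difference in size: the same change on two cores in this assay, a number 18.1 percentage points higher (beyond the scatter) from compound 1 to compound 2 and a number 19.2 percentage points higher (beyond the scatter) from compound 3 to compound 4, 1.1 percentage points apart, within the scatter of two such steps.

Within this series, the methoxy step therefore behaves as a shared increment on these two cores, and an estimate for one core can rest on the step measured on the other. It does not show that the step would hold on any further core, and two instances at a single concentration give neither a potency nor a reason for the increase.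

Whether the step belongs to methoxy itself remains open, as other groups on the same aromatic carbon, such as a hydroxyl, a chlorine or an amine, are not among the compounds shown. Also open is whether the step persists with a shorter or longer chain than those in the compounds shown.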